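A few compounds are considered here, and "the series" means these few. Any claim that something is new, unique, unknown or untested is made for them only; others in the source may bear on it.

Values so far in a functional assay on MCF7 cells (Homo sapiens) for antiproliferative activity, read by MTT assay, with a stated time of 48 h; on this read-out higher numbers stand for weaker inhibition and lower numbers for stronger inhibition
- compound 1 `COc1ccc(-c2c(Nc3ccc(C)c(O)c3)c3ccccc3oc2=O)cc1` gives 12100 nM
- compound 2 `COc1ccc(-c2c(Nc3ccc(NC(C)=O)cc3)c3ccccc3oc2=O)cc1` gives > 100000 nM which is a limit of the assay and not a number

For the measured compounds named here, compound 1 holds the only true number in this assay and sits on the stronger side of this pair. Going by the values given here, the one measured step is an at least 8.2-fold higher number from compound 1 to compound 2 (0.91 log units; beyond the scatter) with 4-acetamidophenyl in place of 3-hydroxy-4-methylphenyl on the nitrogen. On these data alone, that step ends at the limit of > 100000 nM in this assay, at which 1 of the 2 values shown sits, so its full size stays open.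

Compound 3 `COc1ccc(-c2c(Nc3ccc(C)c(O)c3)c3ccc(OC)cc3oc2=O)cc1` keeps the 3-hydroxy-4-methylphenyl group of compound 1 and changes elsewhere, methoxy in place of hydrogen on an aromatic carbon with methoxy in place of hydrogen on an aromatic carbon of the shared core. Among the compounds with values here, no measured step touches this place. Within the data shown here, no step beyond the scatter is therefore expected in this assay, since the only measured change an at least 8.2-fold higher number from compound 1 to compound 2 (0.91 log units; beyond the scatter) lies on the nitrogen substituent and gives no size to carry over. The estimated shift is a 1.2-fold lower number from compound 1 to compound 3 (0.08 log units; within the scatter) and it is expected to stay within the scatter, with no firm direction. For compound 3 the estimate is 10000 nM with an expected range from 3000 nM to 35000 nM in this read-out.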

Compound 3, half-maximal inhibitory concentration: 34400 nM
For compound 3 the middle estimate is 3.4-fold (0.54 log units) below the measured one, within the range that was stated.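

In this assay the shared core proves sensitive to substitution, not only the nitrogen substituent: methoxy in place of hydrogen on an aromatic carbon, meta to a fused ring and para to a fused ring, gives a 2.8-fold higher number from compound 1 to compound 3 (0.45 log units; beyond the scatter) and so counts as a modest loss at this position. Both one-place changes from compound 1 now run toward weaker inhibition, one on the nitrogen substituent and one on the core, and no compound shown goes against this, though two changes are too few to call it a trend for the series. No measurement shown gives a cause for the step at this position.

On these data alone, what a hydroxy group, a fluorine atom or a longer chain such as ethoxy would do on this same carbon remains open, so the step cannot yet be tied to methoxy itself rather than to any substituent at this place. Also open, as far as these compounds go, is whether a methoxy group on another aromatic carbon of the shared core would give a step of similar size, and whether an amine on the nitrogen-bound phenyl ring would change how the core responds.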